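Ethoxycarbonyl on the Pyrrole Ring of Compound 1

A few compounds are considered here, and "the series" means these few. Any claim that something is new, unique, unknown or untested is made for them only; others in the source may bear on it.

Measured compounds:
compound 1 `CCOC(=O)C1=C(Nc2ccccc2)S/C(=C\c2ccc[nH]2)C1=O` gives 9500 nM
compound 2 `CCOC(=O)C1=C(Nc2ccc(C(F)(F)F)cc2)S/C(=C\c2ccc[nH]2)C1=O` gives 46800 nM

Of the compounds shown here, two have been tested in a functional assay on JAR cells (Homo sapiens) for inhibition, read by MTT assay, with a stated time of 72 h; a lower number here means a stronger inhibitor, a higher number a weaker inhibitor. Compound 1 gives the lower of the two numbers; its nearest neighbour is compound 2, and the step of a 4.9-fold higher number from compound 1 to compound 2 (0.69 log units; beyond the scatter) separates them. Compound 3 `CCOC(=O)C1=C(Nc2ccccc2)S/C(=C\c2ccc(C(=O)OCC)[nH]2)C1=O` is not yet measured. It differs from compound 1 by ethoxycarbonyl in place of hydrogen on an aromatic carbon. Within the data shown here, the only measured step alters the phenyl ring on the nitrogen, not the five-membered ring, so it bears on the new change only in showing that a single substituent can move this assay by a modest amount. Among the measured compounds shown here, no measured compound carries any group on the five-membered ring. Compound 3 is therefore expected to stay near compound 1, with a step of a 1.3-fold higher number from compound 1 to compound 3 (0.10 log units; within the scatter) that may fall within the scatter. The estimate for compound 3 is 12000 nM, with a range from 3000 nM to 45000 nM.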

Compound 3, half-maximal inhibitory concentration: 10600 nM
Compound 3: the middle estimate sits 1.1-fold (0.05 log units) above what was measured; low and high end bracket the measured number.
By their numbers in this assay, from the lowest: compounds 1 and 3 (each within the scatter of the next); then compound 2.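

Among the compounds shown, this is the only change on the five-membered aromatic ring: in this assay, ethoxycarbonyl in place of hydrogen, on an aromatic carbon next to the ring nitrogen, gives a 1.1-fold higher number from compound 1 to compound 3 (0.05 log units; within the scatter). This position therefore takes a group of 5 heavy atoms without a shift beyond the scatter, whereas the trifluoromethyl change on the phenyl ring gives a 4.9-fold higher number from compound 1 to compound 2 (0.69 log units; beyond the scatter). Nothing at hand explains why the number holds at this position.

The compounds shown do not tell whether this holds only for ethoxycarbonyl or also for a carboxylic acid, an amine or a longer chain on the same carbon. They also leave open whether ethoxycarbonyl at this position would behave the same way alongside trifluoromethyl on the phenyl ring.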